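This account rests on a few compounds, and the source may have more. Where it says the series, first, only, none or still open, it means among the compounds named here.

Measured in a physicochemical assay for solubility, in phosphate buffer, with a stated time of 18 h, at pH 7.4; on this read-out higher numbers stand for higher solubility and lower numbers for lower solubility:

Compound 1 `COc1cc2ncnc(-n3nc(-c4ccc(Cl)cc4)nc3N)c2cc1OC`: 1000 nM
Compound 2 `COc1cc2ncnc(-n3nc(C4CCCCC4)nc3N)c2cc1OC`: 35000 nM

Compound 2 stands highest of these two. Among the measured compounds shown here, the only measured step is a 35-fold higher number from compound 1 to compound 2 (1.54 log units; beyond the scatter), a large one beyond the scatter, and it concerns the same aromatic carbon that changes next. Compound 3 `COc1cc2ncnc(-n3nc(N)nc3N)c2cc1OC` differs from compound 2 as follows: amino in place of cyclohexyl on an aromatic carbon. For the measured compounds named here, no measured compound carries amino there, so the direction is uncertain, though a modest rise seems likeliest. The expected step is a 1.7-fold higher number from compound 2 to compound 3 (0.23 log units; within the scatter), smaller than the measured one. For compound 3 the estimate is 60000 nM, with an expected range from 15000 nM to 200000 nM.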

Compound 3, solubility: 83000 nM
Compound 3: middle estimate off by 1.4-fold (0.14 log units), on the low side, within the range that was stated.
By their numbers in this assay, from the lowest: compound 1; then compound 2; then compound 3.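

In this assay amino in place of cyclohexyl on this aromatic carbon gives a 2.4-fold higher number from compound 2 to compound 3 (0.38 log units; beyond the scatter) and so is a modest step. Amino in place of 4-chlorophenyl gives an 83-fold higher number from compound 1 to compound 3 (1.92 log units; beyond the scatter) and is a large one, so the three groups at this position now fall in a clear order, with amino highest. Nothing measured here explains that order.

The compounds shown leave open where a methyl, hydroxyl or dimethylamino group on this carbon would fall in that order. They also leave open whether amino keeps its place on a different core.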